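The source may hold more compounds than are shown below. What is called first, only, known or untested is meant among the compounds shown, and "the series" means these compounds.

Of the compounds shown here, three with a shared core have been measured in an ADME assay on microsomes from liver (Homo sapiens) for metabolic stability, using NADPH, with a stated time of 60 min; on this read-out higher numbers stand for fast clearance and lower numbers for slow clearance. Compound 1 `O=C(Nc1cccc(C(=O)O)c1)Nc1ccc(F)c(C(F)(F)F)c1` gives only a limit of that assay, < 7 uL/min. Going by the values given here, compound 2 `O=C(Nc1ccc(F)c(C(F)(F)F)c1)Nc1cnccn1` gives 210 uL/min, the highest of the two numbers measured so far, while compound 3 `NC(=O)c1ccccc1NC(=O)Nc1ccc(F)c(C(F)(F)F)c1` gives 81 uL/min, a gap beyond the usual scatter. Compound 4 `O=C(Nc1cccnc1)Nc1ccc(F)c(C(F)(F)F)c1` has not yet been measured and differs from compound 2 in one place: pyridin-3-yl in place of pyrazin-2-yl on an amide-type nitrogen. Among the compounds with values here, no measured pair shows a change of this kind, so its effect in this assay is open. The expected step is a 1.2-fold lower number from compound 2 to compound 4 (0.07 log units; within the scatter), small. The estimate for compound 4 is 180 uL/min, between 80 uL/min and 400 uL/min.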

Compound 4, intrinsic clearance in a liver preparation (reported as CLH), per the amount of preparation that the assay uses in the Homo sapiens assay: 13 uL/min
Compound 4: middle estimate off by 14-fold (1.14 log units), on the high side; measured number outside the range, below it.
By their numbers in the Homo sapiens assay, from the lowest: compound 4; then compound 3; then compound 2. At a limit, below all of these: compound 1.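

In the Homo sapiens assay, this one ring change on an amide-type nitrogen gives a 16-fold lower number from compound 2 to compound 4 (1.21 log units; beyond the scatter), so the number at this place depends strongly on which ring sits there, even with the same count of heavy atoms. In a physicochemical assay for solubility, read by nephelometry, in phosphate buffer, measured as kinetic solubility, at pH 6.5 (a higher number here means a more soluble compound, a lower number a less soluble compound), compound 2 gives < 1.6 ug/mL, a limit of that assay: the limit of < 1.6 ug/mL in the physicochemical assay, at which 1 of the 2 values shown sits. In the physicochemical assay compound 4 gives 12.5 ug/mL, a measured number.

This change appears in one pair only. As far as these compounds go, whether another ring on the same nitrogen, such as phenyl or pyrimidinyl, would lower the number in the Homo sapiens assay as far remains open.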